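A few compounds are considered here, and "the series" means these few. Any claim that something is new, unique, unknown or untested is made for them only; others in the source may bear on it.

Two measured members of the series share a common core. Compound 1 `CCCNS(=O)(=O)c1ccc(Nc2ncc3c(n2)N(C2CCCC2)[C@H](CC)C(=O)N3C)cc1` is the more potent of the pair: in a functional assay on HeLa cells (Homo sapiens) for antiproliferative activity, read by CCK-8 assay, with a stated time of 72 h (a lower number here means a stronger inhibitor of growth, a higher number a weaker inhibitor of growth), compound 1 gives 459 nM. Compound 2 `CCC1C(=O)N(C)c2cnc(-n3ccc4cc(C(=O)NC)ccc43)nc2N1c1ccn(C)n1` carries a different arm on that core, and in this assay compound 2 gives 6330 nM, the higher of the two numbers in hand; the gap to compound 1 lies beyond the scatter. Among the measured compounds shown here, no pair of measured compounds differing in a single place is available, so no single change has yet been sized. Compound 3 `CCCCNC(=O)c1ccc2c(ccn2-c2ncc3c(n2)N(c2ccn(C)n2)C(CC)C(=O)N3C)c1` differs from compound 2 in one place: propyl in place of hydrogen on a saturated chain carbon bound to an amide-type nitrogen. For the measured compounds named here, no measured compound bears on this change. The step from compound 2 to compound 3 is expected to be small, a 1.4-fold lower number from compound 2 to compound 3 (0.15 log units; within the scatter), with no direction clearly beyond the scatter. For compound 3 in this assay the estimate is 4500 nM, within a range of 1500 nM to 13000 nM.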

Compound 3, concentration for 50% growth inhibition: 4260 nM
The estimate for compound 3 lay 1.1-fold (0.02 log units) above the measured number, and the stated range covers the measured number.
By their numbers in this assay, from the lowest: compound 1; then compounds 3 and 2 (each within the scatter of the next).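

The step from hydrogen to propyl, read one bond further out as methylcarbamoyl to butylcarbamoyl, gives the series its first sized single change: in this assay, a 1.5-fold lower number from compound 2 to compound 3 (0.17 log units; within the scatter). At this saturated chain carbon bound to an amide-type nitrogen, then, adding propyl does not move the number beyond the scatter, so this one change neither gains nor loses measurable antiproliferative activity. No measurement available here offers an explanation for this flat step.

As far as these compounds go, whether the flat response extends to a longer chain such as octyl, or to a butyl chain ending in an amine or a carboxylic acid, remains open. Also open, from the compounds shown here alone, is whether a ring such as cyclopropyl or phenyl at the same place would give a step beyond the scatter.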